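The source may hold more compounds than are shown below. What is called first, only, known or untested is meant among the compounds shown, and "the series" means these compounds.

Three compounds of one series share a common core: compound 1 `CCCC1(C)SC(NC2CCCCC2)=NC1=O`, compound 2 `CCCC1(C)SC(NC2CCCCCCC2)=NC1=O` and compound 3 `CCC1(C)SC(NC2CCCCC2)=NC1=O`. All three were examined in an assay on HEK293 cells for binding affinity to 11-beta-hydroxysteroid dehydrogenase type 2 (Homo sapiens), read by scintillation proximity assay; on this read-out lower numbers stand for stronger inhibition and higher numbers for weaker inhibition. For compound 1 the record reads "not determined" (no result reported), and for compound 3 it likewise reads "not determined" (no result reported). Within the data shown here, compound 2 therefore stands alone as the only member with any number attached, and in this assay compound 2 gives > 10000 nM. That figure is a limit of the assay rather than a measured value, as noted in the limit of > 10000 nM in this assay, at which 1 of the 3 values shown sits.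

Compound 4 `CCC1(C)SC(NC2CCCCCCC2)=NC1=O` has not yet been measured. It differs from compound 2 in one place: hydrogen in place of methyl on a saturated chain carbon, two bonds along the chain from a saturated ring carbon. Put another way, the propyl becomes ethyl. Among the measured compounds shown here, no pair of measured compounds shows this kind of step, so the expectation rests on compound 2 alone. The step from compound 2 to compound 4 is expected to be a step that the limit leaves unreadable from compound 2 to compound 4, meaning no change beyond the scatter. For compound 4 the estimated value in this assay is 15000 nM. The expected range for compound 4 runs from 5000 nM to 50000 nM, with a strong chance that only a limit is reported again.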

Compound 4, half-maximal inhibitory concentration: > 10000 nM
Compound 4 was reported as a limit; the forecaster's own chance of this, stated with the estimate: 75%; the middle value lies beyond the limit too.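

Compound 2 and compound 4 are both reported only as limits in this assay, so the change from propyl to ethyl has no readable size: the limit of > 10000 nM in this assay, at which 2 of the 4 values shown sit.

The compounds shown leave open how strongly either compound inhibits and whether swapping propyl for ethyl changes that at all.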